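Ethynyl Added to a Methoxy Group: Expected Effect

The source may report more compounds than this note shows. Statements on the series, on what has been measured and on what is new or still open speak of the compounds shown alone.

In a functional assay on COLO 205 cells (Homo sapiens) for cytotoxicity, read by MTT assay, with a stated time of 72 h (a higher number here means a weaker inhibitor, a lower number a stronger inhibitor), compound 2 `COc1cccc(/C=C/C(=O)Nc2cc(C(=O)c3cc(OC)c(OC)c(OC)c3)ccc2OC)c1` gives 5100 nM. Compound 1 `COc1ccc(C(=O)c2cc(OC)c(OC)c(OC)c2)cc1NC(=O)/C=C/c1cc(OC)c(OC)c(OC)c1` gives 5200 nM. The step of a 1.0-fold lower number from compound 1 to compound 2 (0.01 log units; within the scatter) lies within the scatter, so these two numbers cannot be told apart. Compound 3 `C#CCOc1cccc(/C=C/C(=O)Nc2cc(C(=O)c3cc(OC)c(OC)c(OC)c3)ccc2OC)c1` carries ethynyl in place of hydrogen on a saturated chain carbon bound to an oxygen on an aromatic ring; cut one bond further out, this reads methoxy to propargyloxy. Among the measured compounds shown here, only the step from compound 1 to compound 2 alters this same ring, and it moved nothing beyond the scatter, so for compound 3 in this assay no step beyond the scatter is expected, the estimated step being a 1.0-fold lower number from compound 2 to compound 3 (0.01 log units; within the scatter). Compound 3 is estimated at 5000 nM, between 1500 nM and 16000 nM.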

Compound 3, half-maximal inhibitory concentration: 13400 nM
Compound 3: middle estimate off by 2.7-fold (0.43 log units), on the low side, within the range that was stated.
By their numbers in this assay, from the lowest: compounds 2 and 1 (each within the scatter of the next); then compound 3.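

This position is not indifferent to change. In this assay, adding ethynyl to the methoxy group weakens the compound (a 2.6-fold higher number from compound 2 to compound 3 (0.42 log units; beyond the scatter)), whereas the earlier change on this ring moved nothing beyond the scatter. The same direction appears against the trimethoxy compound (a 2.6-fold higher number from compound 1 to compound 3 (0.41 log units; beyond the scatter)). Nothing available here explains why the number rises.

The compounds shown leave open whether the rise follows from the ethynyl itself or simply from a longer chain on this oxygen. A propoxy group, with no triple bond, would separate the two, and a free hydroxyl would show what a shorter group does here.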